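Notes on aryl replacement at the shared core

A few compounds are considered here, and "the series" means these few. Any claim that something is new, unique, unknown or untested is made for them only; others in the source may bear on it.

Measured so far in a functional assay on HCT-116 cells (Homo sapiens) for inhibition, read by CCK-8 assay, with a stated time of 48 h; on this read-out lower numbers stand for stronger inhibition and higher numbers for weaker inhibition:
- compound 1 `COc1cc(-c2ccnc3cc(-c4cn(C)c5ccccc45)nn23)cc(OC)c1OC`: 762 nM
- compound 2 `COc1cc(-c2ccnc3cc(-c4cn(C(=O)OC(C)(C)C)c5ccccc45)nn23)cc(OC)c1OC`: 5720 nM
- compound 3 `COc1cc(-c2ccnc3cc(-c4cccc5c4ccn5CO)nn23)cc(OC)c1OC`: 861 nM

Compound 1 gives the lowest number of the three in this assay. Compound 3 sits within the scatter of it, so no order between compound 1 and compound 3 can be read from these two values. Among the compounds with values here, the only single-point step recorded is a 7.5-fold higher number from compound 1 to compound 2 (0.88 log units; beyond the scatter), which moves the number upward by a modest amount.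

Compound 4 `COc1cc(-c2ccnc3cc(-c4ccc(C(C)(C)C)cc4)nn23)cc(OC)c1OC` is not yet measured. Relative to compound 1 the change is 4-(tert-butyl)phenyl in place of 1-methyl-1H-indol-3-yl on an aromatic carbon. Within the data shown here, none of the measured steps bears directly on this change: the step from compound 1 to compound 2 alters only the substituent on the indole nitrogen, and compound 3 differs from compound 1 in more than one place, so no step is given for it. The exchange of the whole group at the five-membered ring of the shared core is therefore unsupported by any step shown, and the expectation must rest on the general observation that the indole-bearing compounds cluster near compound 1 while the one departure, compound 2, went weaker.

Compound 4 is expected to give a higher number, with the step of a 2.6-fold higher number from compound 1 to compound 4 (0.42 log units; beyond the scatter) likely beyond the scatter but uncertain in size. The estimate for compound 4 in this assay is 2000 nM, within a range of 600 nM to 8000 nM.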

Compound 4, half-maximal inhibitory concentration: > 10000 nM
Compound 4: only a limit was reported (the forecaster's own chance of this, stated with the estimate: 5%); middle value at least 5.0-fold (0.69 log units) from the limit.
By their numbers in this assay, from the lowest: compounds 1 and 3 (each within the scatter of the next); then compound 2. At a limit, above all of these: compound 4.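

Replacing 1-methyl-1H-indol-3-yl with 4-(tert-butyl)phenyl on the aromatic carbon of the five-membered ring of the shared core gives an at least 13-fold higher number from compound 1 to compound 4 (1.11 log units; beyond the scatter) in this assay. Compound 4 gives > 10000 nM, which is a limit of the assay and not a number: the limit of > 10000 nM in this assay, at which 1 of the 4 values shown sits.

The earlier step, a 7.5-fold higher number from compound 1 to compound 2 (0.88 log units; beyond the scatter), altered only the substituent on the indole nitrogen, whereas this result shows that the number also responds to exchange of the whole group on the carbon, even though the leaving and entering groups both hold 10 heavy atoms.

The change removes the indole's five-membered ring and its nitrogen and adds the tert-butyl in a single exchange, so the compounds shown cannot assign the loss to any one of these parts. An unsubstituted phenyl, or a phenyl carrying an amine or a carboxylic acid in place of tert-butyl, would be needed to tell whether any six-membered aromatic ring can be tolerated here or whether the result is specific to 4-(tert-butyl)phenyl.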